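The compounds below may be only part of what the source reports. "The series", "measured", "known", "first", "only" and "open" are said of these compounds alone.

Of the compounds shown here, two have so far been measured in a physicochemical assay for solubility, read by HPLC, in simulated intestinal fluid, with a stated time of 16 h, tested at 125 ug/mL; a higher number here means a more soluble compound, a lower number a less soluble compound. Compound 1 `CNC(=O)c1cc(C(=O)NC2CC2)cn(Cc2cccc(F)c2)c1=O` gives 31 ug/mL in this assay, and compound 2 `CNC(=O)c1cc(C(=O)NC2CCC2)cn(Cc2cccnc2)c1=O` gives 189 ug/mL in this assay, so compound 1 holds the lower of the two numbers, and the gap to compound 2 lies beyond the scatter. Compound 3 `CNC(=O)c1cc(C(=O)NC2CC2)cn(Cc2ccccc2F)c1=O` is not yet measured. It differs from compound 1 in one place: 2-fluorophenyl in place of 3-fluorophenyl on a saturated chain carbon bound to an aromatic nitrogen. Going by the values given here, no measured pair shows a change of this kind, so the expected step is a 1.1-fold higher number from compound 1 to compound 3 (0.05 log units; within the scatter), small and within the scatter in either direction. Compound 3 is estimated at 35 ug/mL, within 15 ug/mL to 85 ug/mL.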

Compound 3, solubility: 88 ug/mL
Estimate against measurement, compound 3: 2.5-fold (0.40 log units) below; measured number above the stated range.
By their numbers in this assay, from the lowest: compound 1; then compound 3; then compound 2.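

In this assay, 2-fluorophenyl in place of 3-fluorophenyl gives a 2.8-fold higher number from compound 1 to compound 3 (0.45 log units; beyond the scatter) even though the two compounds hold the same atoms. At this position, on a saturated chain carbon bound to an aromatic nitrogen, where the fluorine sits on the ring is therefore enough to move the number beyond the scatter. Nothing at hand explains the shift. Still open, going by these compounds, is how this assay would read with a chlorine atom, a methoxy group or an amine in place of the fluorine. Going by these compounds alone, only this one pair carries the swap, so whether it holds with other amides on the shared core is also unknown.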